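The compounds below may be only part of what the source reports. "The series", "measured", "known", "first", "only" and "open" are said of these compounds alone.

The series shares the core seen in compound 1 `COc1ccc2[nH]c3c(c2c1)CCNC31CCN(Cc2ccccc2)CC1`, compound 2 `COc1ccc2[nH]c3c(c2c1)CCNC31CCN(Cc2ccc(Br)cc2F)CC1` and compound 3 `COc1ccc2[nH]c3c(c2c1)CCNC31CCN(Cc2cc(F)cc(F)c2)CC1`, differing only in the group carried on the amine nitrogen in the ring. In an assay on FRT cells for positive allosteric modulation of Cystic fibrosis transmembrane conductance regulator variant N1303K (Homo sapiens), in the presence of a further agent that is not named here (on this read-out lower numbers stand for an effect already at smaller amounts and higher numbers for an effect only at larger amounts of compound), compound 1 gives 12600 nM, compound 2 gives 1600 nM and compound 3 gives 11100 nM. Compound 3 thus holds the second highest of the three numbers; it sits closest to compound 1, as the step of a 1.1-fold lower number from compound 1 to compound 3 (0.06 log units; within the scatter) shows, and furthest from compound 2, as the step of a 6.9-fold higher number from compound 2 to compound 3 (0.84 log units; beyond the scatter) shows.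

Compound 4 `COc1ccc2[nH]c3c(c2c1)CCNC31CCN(C(C)c2ccccc2)CC1` is the next member, and its change from compound 3 is 1-phenylethyl in place of 3,5-difluorobenzyl on an amine nitrogen in a ring. Two parts make up this change. Going by the values given here, removing the two fluorines is the reverse of a step already seen, since a 1.1-fold lower number from compound 1 to compound 3 (0.06 log units; within the scatter) lay within the scatter; adding the methyl on the saturated carbon that joins the phenyl to the ring nitrogen has no measured counterpart here. The step of a 7.9-fold lower number from compound 1 to compound 2 (0.90 log units; beyond the scatter) concerns a different substitution pattern and does not speak to this change. Compound 4 is therefore expected to give 11000 nM, with a range from 4000 nM to 30000 nM. The step that this estimate implies from compound 3 is expected to be a 1.0-fold lower number from compound 3 to compound 4 (0.00 log units; within the scatter), that is, no change beyond the scatter.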

Compound 4, half-maximal effective concentration: 20000 nM
Estimate against measurement, compound 4: 1.8-fold (0.26 log units) below; the measured number falls inside the stated range.
By their numbers in this assay, from the lowest: compound 2; then compounds 3, 1 and 4 (each within the scatter of the next).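

Going by these compounds alone, the first direct reading on the saturated chain carbon bound to the ring nitrogen and the phenyl comes from a 1.6-fold higher number from compound 1 to compound 4 (0.20 log units; within the scatter): in this assay, a methyl in place of hydrogen at this carbon leaves the two compounds within the scatter of each other. The full exchange of 3,5-difluorobenzyl for 1-phenylethyl, a 1.8-fold higher number from compound 3 to compound 4 (0.26 log units; within the scatter), also stays within the scatter, so compounds 1, 3 and 4 cannot be separated, while a 13-fold higher number from compound 2 to compound 4 (1.10 log units; beyond the scatter) sets compound 4 clearly apart from the 4-bromo-2-fluorobenzyl compound and leaves compound 2 as the only one distinct from the rest. Nothing available here explains any of these steps.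

Going by these compounds, it remains open whether the methyl would also sit within the scatter when carried together with the 4-bromo-2-fluorophenyl group of compound 2, since the step from compound 1 to compound 4 was read only on an unsubstituted phenyl. The compounds shown also leave open how an ethyl or a hydroxymethyl on that chain carbon would read, and whether bromine alone or fluorine alone on the phenyl would account for the lower number of compound 2.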